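The source may hold more compounds than are shown below. What is called first, only, known or untested is meant among the compounds shown, and "the series" means these compounds.

Measured compounds:
compound 1, `N=C(S)CCn1nc(-c2ccccc2)ccc1=S`, giving 62.3%;
compound 2, `N=C(S)CCn1ncccc1=S`, giving 50%.

Among the compounds with values here, in a functional assay on the whole organism (stomach) for inhibition, with Rattus norvegicus as the target, at a dose of 100 mg/kg by the intraduodenal route (on this read-out higher numbers stand for more inhibition at the one dose given (going by the name of the read-out) and lower numbers for less inhibition), compound 2 stands lowest of the two numbers, with compound 1 the only neighbour and the step of a number 12.3 percentage points lower from compound 1 to compound 2 (beyond the scatter) setting the gap between them. Compound 3, `Cc1ccc(=S)n(CCC(=N)S)n1`, has not yet been measured. It differs from compound 2 by methyl in place of hydrogen on an aromatic carbon. Within the data shown here, the one measured step that bears on it is the one from compound 1 to compound 2, where a number 12.3 percentage points lower from compound 1 to compound 2 (beyond the scatter) followed the loss of a phenyl group from an aromatic carbon; adding a methyl group at an aromatic carbon is a much smaller change, so the expected move in this assay is upward at most modestly, quite possibly within the scatter, giving an expected step of a number 5 percentage points higher from compound 2 to compound 3 (within the scatter). Compound 3 is therefore expected to give about 55% in this assay, between 40% and 70%.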

Compound 3, a percentage reported as inhibition, in the whole organism at one dose (the size of the read-out at that dose, not a potency): 48.5%
Compound 3: the middle estimate sits 6.5 percentage points above what was measured, and the stated range covers the measured number.
By their numbers in this assay, from the lowest: compounds 3 and 2 (each within the scatter of the next); then compound 1.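

In this assay, methyl in place of hydrogen on this aromatic carbon brings a number 1.5 percentage points lower from compound 2 to compound 3 (within the scatter), so adding this one carbon produces no readable change at this position, something the earlier pair could not show. Methyl in place of phenyl brings a number 13.8 percentage points lower from compound 1 to compound 3 (beyond the scatter), which makes phenyl the one group of the three at this position that stands apart, while hydrogen and methyl cannot be told apart. Nothing at hand explains why phenyl stands apart from the other two.

The compounds shown leave open whether the higher number needs an aromatic ring here or whether a longer chain such as butyl or a cyclohexyl ring would serve as well. They also leave open how a phenyl ring carrying a chlorine, or an amine or a carboxylic acid at this carbon, would read out.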